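Notes on the thiocarbonyl amine change in compound 4

The source may hold more compounds than are shown below. What is called first, only, known or untested is meant among the compounds shown, and "the series" means these compounds.

In a functional assay on MCF7 cells (Homo sapiens) for cytotoxicity, read by MTT assay, with a stated time of 72 h, tested at 10 uM (on this read-out lower numbers stand for less inhibition of growth and higher numbers for more inhibition of growth at the one concentration tested), compound 1 `N/C(=N\NC(=S)N1CCOCC1)c1ccccn1` gives 66.7%. Compound 2 `N/C(=N\NC(=S)N1CCSCC1)c1ccccn1` gives 54.3% in this assay, and compound 3 `Cc1cccc(/C(N)=N/NC(=S)N2CCOCC2)n1` gives 39.1%. Compound 3 thus stands lowest of the three numbers; its nearest neighbour is compound 2 and its furthest is compound 1, and both gaps lie beyond the scatter. Two single changes have been measured so far: a number 12.4 percentage points lower from compound 1 to compound 2 (beyond the scatter) and a number 27.6 percentage points lower from compound 1 to compound 3 (beyond the scatter). Compound 4 `Cc1cccc(/C(N)=N/NC(=S)N2CCCC2)n1` is not yet measured; it differs from compound 3 by pyrrolidin-1-yl in place of morpholin-4-yl on a thiocarbonyl carbon. For the measured compounds named here, only the step from compound 1 to compound 2 concerns the same place, the thiocarbonyl carbon, and there the exchange of the amine lowered the number modestly; no measured step tries pyrrolidin-1-yl at that carbon, so the direction is not fixed by the data. A small lowering, or a step within the scatter, is expected, a number 5.1 percentage points lower from compound 3 to compound 4 (within the scatter). For compound 4 the expected value is 34%, with a range from 18% to 52%.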

Compound 4, percent growth inhibition at one concentration: 38.2%
Compound 4: middle estimate off by 4.2 percentage points, on the low side, within the range that was stated.
By their numbers in this assay, from the lowest: compounds 4 and 3 (each within the scatter of the next); then compound 2; then compound 1.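

In this assay, pyrrolidin-1-yl in place of morpholin-4-yl on a thiocarbonyl carbon gives a number 0.9 percentage points lower from compound 3 to compound 4 (within the scatter), so this pair shows an amine exchange at this carbon that the read-out does not resolve, even though the ring size and the ring oxygen both differ. For the compounds shown here, the only other amine exchange at this carbon, a number 12.4 percentage points lower from compound 1 to compound 2 (beyond the scatter), stands on the core of compound 1, which lacks the methyl group of compound 3, so the two steps do not yet add up to a rule for this position. Nothing at hand explains the outcome of either exchange.

Open, on these data alone, is whether pyrrolidin-1-yl gives a similar result on the core of compound 1. Also open, as far as these compounds go, is how a piperazin-1-yl ring or an open-chain dimethylamino group would read at the same thiocarbonyl carbon.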